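This account rests on a few compounds, and the source may have more. Where it says the series, first, only, none or still open, it means among the compounds named here.

Compound 1 `C1=C(c2cncc(OCc3ccccc3)c2)CC2CNCC1C2` gives 44 nM in an in vitro assay on SH-SY5Y cells for displacement of a labelled ligand from Neuronal acetylcholine receptor; alpha3/beta4 (Homo sapiens); a lower number here means a stronger inhibitor, a higher number a weaker inhibitor. Compound 2 `Clc1ccccc1Oc1cncc(C2=CC3CNCC(C2)C3)c1` gives 26 nM.

Within the data shown here, on these two numbers compound 2 and compound 1 lie within the scatter of each other, so neither stands apart; the only measured step, a 1.7-fold lower number from compound 1 to compound 2 (0.23 log units; within the scatter), was itself within the scatter. Compound 3 `Clc1cccc(Oc2cncc(C3=CC4CNCC(C3)C4)c2)c1` differs from compound 2 by 3-chlorophenyl in place of 2-chlorophenyl on an oxygen on an aromatic ring. Among the measured compounds shown here, no measured step concerns a shift of the chlorine on this ring, and the one step known bears on it only loosely, so compound 3 is expected to show no step beyond the scatter: a 1.1-fold higher number from compound 2 to compound 3 (0.03 log units; within the scatter). Compound 3 is estimated at 28 nM, with a range from 10 nM to 80 nM.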

Compound 3, inhibition constant: 22 nM
Beside the measured number, compound 3's estimate is 1.3-fold (0.10 log units) above it, within the range that was stated.
By their numbers in this assay, from the lowest: compounds 3, 2 and 1 (each within the scatter of the next).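

In this assay, moving the chlorine on this ring gives a 1.2-fold lower number from compound 2 to compound 3 (0.07 log units; within the scatter) and so shows no measurable preference between 3-chlorophenyl and 2-chlorophenyl on the oxygen. The change from benzyl to 3-chlorophenyl gives a 2.0-fold lower number from compound 1 to compound 3 (0.30 log units; within the scatter) and also stays inside the scatter, so the three groups tested here read alike. Nothing available gives a reason for this sameness.

As far as these compounds go, it remains open whether a methoxy group or an amine on this ring, in place of the chlorine, would move the number beyond the scatter.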